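Adding a fluoro group to compound 3

A few compounds are considered here, and "the series" means these few. Any claim that something is new, unique, unknown or untested is made for them only; others in the source may bear on it.

Measured in a functional assay on SGC-7901 cells (Homo sapiens) for antiproliferative activity, read by MTT assay, with a stated time of 48 h; on this read-out higher numbers stand for an effect only at larger amounts of compound and lower numbers for an effect already at smaller amounts:
Compound 1 `CC1=NN(C(=O)CCl)C(c2cc(Cl)ccc2O)C1` gives 14000 nM
Compound 2 `CC1=NN(C(=O)C(F)(F)F)C(c2ccccc2O)C1` gives 2060 nM
Compound 3 `CC1=NN(S(=O)(=O)c2ccccc2)C(c2cc(Br)ccc2O)C1` gives 55600 nM

Compound 3 has the highest number of the three, beyond the usual scatter from both compound 1 and compound 2. Compound 4 `CC1=NN(S(=O)(=O)c2ccc(F)cc2)C(c2cc(Br)ccc2O)C1` has fluoro in place of hydrogen on an aromatic carbon of compound 3, which turns phenyl to 4-fluorophenyl (fluoro in place of hydrogen on an aromatic carbon). For the measured compounds named here, no two measured compounds differ in only one place, and the data offer no direct guide to this change. In this assay only a small drop in the number is therefore expected, with no step beyond the scatter: the estimated change is a 1.2-fold lower number from compound 3 to compound 4 (0.09 log units; within the scatter) as a rough guess. Compound 4 is expected near 45000 nM, with an estimated range of 14000 nM to 120000 nM here.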

Compound 4, half-maximal effective concentration: > 60000 nM
Compound 4: a limit, no number; the forecaster's own chance of this, stated with the estimate: 10%; middle value at least 1.3-fold (0.12 log units) away from the limit.
By their numbers in this assay, from the lowest: compound 2; then compound 1; then compound 3. At a limit, above all of these: compound 4.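

In this assay compound 4 gives > 60000 nM, which is a limit of the assay and not a number. For the compounds shown here, this is the first step between compounds that differ in one place, and it can be read only as a floor: an at least 1.0-fold higher number from compound 3 to compound 4 (0.03 log units; that floor lies within the scatter). Fluoro on this aromatic ring gives no sign of a lower number, but whether the number really rises stays unknown because the value is a limit: the limit of > 60000 nM in this assay, at which 1 of the 4 values shown sits.

From the compounds shown here alone, it remains open how an amine or a methoxy group in the same place would behave.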